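A few compounds are considered here, and "the series" means these few. Any claim that something is new, unique, unknown or untested is made for them only; others in the source may bear on it.

Compound 3 `O=C(CCN(Cc1ccc(C(=O)NO)cc1)C(=O)c1ccccc1)NCc1ccccc1` is the weakest of the three compounds whose numbers are known: in a functional assay on G55T2 cells (Homo sapiens) for antiproliferative activity, read by WST assay, with a stated time of 72 h (on this read-out higher numbers stand for weaker inhibition and lower numbers for stronger inhibition), compound 3 gives 5940 nM. Compound 1 `Cc1ccc(NC(=O)CCN(Cc2ccc(C(=O)NO)cc2)C(=O)c2cc(C)cc(C)c2)cc1` gives 370 nM in this assay, and compound 2 `Cc1ccc(NC(=O)CCN(Cc2ccc(C(=O)NO)cc2)C(=O)c2ccc(N(C)C)cc2)cc1` gives 330 nM, so compound 3 stands well beyond the scatter from both of them. Compound 4 `Cc1ccc(C(=O)N(CCC(=O)NCc2ccccc2)Cc2ccc(C(=O)NO)cc2)cc1` differs from compound 3 in one place: methyl in place of hydrogen on an aromatic carbon. For the measured compounds named here, only one measured step speaks to a change on the benzoyl part of the core, the step of a 1.1-fold lower number from compound 1 to compound 2 (0.05 log units; within the scatter), which swapped one substituted aryl for another on the carbonyl carbon without moving the number beyond the scatter. That swap was larger than a single methyl, and nothing in the data ties a methyl on this ring to a gain or loss. The step of a 1.1-fold lower number from compound 3 to compound 4 (0.03 log units; within the scatter) is therefore expected to stay within the scatter, perhaps a touch weaker. Compound 4 is estimated at 5500 nM in this assay, with a range from 2200 nM to 14000 nM.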

Compound 4, half-maximal inhibitory concentration: 690 nM
The estimate for compound 4 lay 8.0-fold (0.90 log units) above the measured number; the whole stated range lies above it.
By their numbers in this assay, from the lowest: compounds 2, 1 and 4 (each within the scatter of the next, the first and the last beyond it); then compound 3.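

With an 8.6-fold lower number from compound 3 to compound 4 (0.93 log units; beyond the scatter) in this assay, this position proves sensitive to substitution: one methyl on an aromatic carbon, para to a large group, moves the number beyond the scatter towards stronger inhibition. The earlier step, a 1.1-fold lower number from compound 1 to compound 2 (0.05 log units; within the scatter), stayed within the scatter, but it replaced one substituted aryl with another and so never set a substituted ring against the plain benzoyl of compound 3. Nothing measured here accounts for this gain.

Going by these compounds, it remains open whether the gain is particular to methyl or would also come with a chlorine atom, a methoxy group or an ethyl group at this place. Also open, on these data alone, is whether a methyl on another carbon of the ring would give a step of similar size.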